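Amide variation on the hexafluoropropanol naphthalene core

A few compounds are considered here, and "the series" means these few. Any claim that something is new, unique, unknown or untested is made for them only; others in the source may bear on it.

Three amides on the shared core have been measured in an assay on LtK cells with ATP-sensitive inward rectifier potassium channel 11 (Homo sapiens) as the target; on this read-out lower numbers stand for an effect already at smaller amounts and higher numbers for an effect only at larger amounts of compound. Compound 1 `CCC(=O)Nc1c(C(O)(C(F)(F)F)C(F)(F)F)ccc2ccccc12`, the propanamide, gives 15 nM. Compound 2 `O=C(Nc1c(C(O)(C(F)(F)F)C(F)(F)F)ccc2ccccc12)c1cccc([N+](=O)[O-])c1` gives 117 nM, and compound 3 `O=C(Nc1c(C(O)(C(F)(F)F)C(F)(F)F)ccc2ccccc12)c1ccc(C(F)(F)F)cc1` gives 160 nM. Compound 3 stands at the highest number of the three; its neighbour compound 2 lies within the scatter of it, while the gap to compound 1 is beyond the scatter. The two aryl amides thus sit together in the same range, away from the ethyl amide.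

Compound 4 `O=C(Nc1c(C(O)(C(F)(F)F)C(F)(F)F)ccc2ccccc12)c1cccnc1` is the next aryl amide: pyridin-3-yl in place of 4-(trifluoromethyl)phenyl on a carbonyl carbon. Two measured steps show an aryl group entering in place of ethyl, a 7.8-fold higher number from compound 1 to compound 2 (0.89 log units; beyond the scatter) and an 11-fold higher number from compound 1 to compound 3 (1.03 log units; beyond the scatter), both clearly beyond the scatter. Going by the values given here, the only aryl-to-aryl step, a 1.4-fold higher number from compound 2 to compound 3 (0.14 log units; within the scatter), is within the scatter. Among the compounds with values here, the change to compound 4 is again aryl-to-aryl, so the nearer precedent is the step from compound 2 to compound 3, and no step beyond the scatter is expected in either direction, with a wide margin since only one such exchange has been seen.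

Compound 4 is therefore expected to give about 130 nM in this assay, with a range from 45 nM to 400 nM, which corresponds to an expected step of a 1.2-fold lower number from compound 3 to compound 4 (0.09 log units; within the scatter).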

Compound 4, half-maximal effective concentration: 60 nM
Compound 4: middle estimate off by 2.2-fold (0.34 log units), on the high side; measured number inside the range.
By their numbers in this assay, from the lowest: compound 1; then compounds 4, 2 and 3 (each within the scatter of the next, the first and the last beyond it).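

In this assay, an exchange of one aryl group for another on this carbonyl carbon can move the number beyond the scatter, as a 2.7-fold lower number from compound 3 to compound 4 (0.43 log units; beyond the scatter) shows, so the aryl amides no longer read as a single range. With a 2.0-fold lower number from compound 2 to compound 4 (0.29 log units; within the scatter), the pyridin-3-yl and 3-nitrophenyl amides cannot be told apart, while the ethyl amide stays separate from the pyridin-3-yl amide, with a 4.0-fold higher number from compound 1 to compound 4 (0.60 log units; beyond the scatter), as it does from the other two aryl amides. Nothing available accounts for the separation of the pyridin-3-yl amide from the 4-(trifluoromethyl)phenyl amide.

Open, on these data alone, is whether the aromatic ring itself or the groups and hetero atom it carries set the position of the aryl amides, which the plain phenyl amide would address, together with the pyridin-4-yl amide for the place of the ring nitrogen. On the alkyl side, ethyl stands alone, so a longer chain such as butyl, or a cyclopropyl group, would show how far the number of compound 1 extends beyond that single group.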